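Shrinking the amide ring substituent: compound 2 to compound 4

A few compounds are considered here, and "the series" means these few. Any claim that something is new, unique, unknown or untested is made for them only; others in the source may bear on it.

Measured compounds and their results in a functional assay on A549 cells (Homo sapiens) for inhibition, read by sulforhodamine B assay, with a stated time of 72 h; on this read-out higher numbers stand for weaker inhibition and lower numbers for stronger inhibition:
- compound 1, `Nc1sc(-c2ccc(Cl)cc2)c(-c2ccc(Cl)cc2)c1C(=O)NC1CCC(O)CC1`, gives 250 nM
- compound 2, `Nc1sc(-c2ccc(Cl)cc2)c(-c2ccc(Cl)cc2)c1C(=O)NC1CCCCC1`, gives 2410 nM
- compound 3, `Nc1sc(-c2ccc(Cl)cc2)c(-c2ccc(Cl)cc2)c1C(=O)N1CCNCC1`, gives 1020 nM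

Compound 2 has the highest number of the three in this assay; its nearest neighbour is compound 3, its furthest compound 1. Compound 4, `Nc1sc(-c2ccc(Cl)cc2)c(-c2ccc(Cl)cc2)c1C(=O)NC1CC1`, differs from compound 2 in one place: cyclopropyl in place of cyclohexyl on an amide-type nitrogen. Within the data shown here, two measured steps touch the same amide position. The change from compound 1 to compound 2, a hydroxy removed from the saturated ring, gave a 9.6-fold higher number from compound 1 to compound 2 (0.98 log units; beyond the scatter). Replacing the cyclohexylamino group by piperazin-1-yl gave a 2.4-fold lower number from compound 2 to compound 3 (0.37 log units; beyond the scatter). Neither step tests a smaller carbocycle with no donors or acceptors, so the closest analogy is the bare cyclohexyl of compound 2 itself. The author therefore expects compound 4 to land near compound 2 in this assay, with a step of a 1.2-fold lower number from compound 2 to compound 4 (0.08 log units; within the scatter), likely within the scatter. The estimate for compound 4 is 2000 nM, with a range from 700 nM to 6000 nM.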

Compound 4, half-maximal inhibitory concentration: 1950 nM
Estimate against measurement, compound 4: 1.0-fold (0.01 log units) above, within the range that was stated.
By their numbers in this assay, from the lowest: compound 1; then compounds 3, 4 and 2 (each within the scatter of the next, the first and the last beyond it).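

In this assay, cyclopropyl and cyclohexyl on the amide-type nitrogen cannot be told apart, with a 1.2-fold lower number from compound 2 to compound 4 (0.09 log units; within the scatter), and compound 4 also lies within the scatter of the piperazin-1-yl amide, with a 1.9-fold higher number from compound 3 to compound 4 (0.28 log units; within the scatter), although compound 2 and compound 3 lie beyond the scatter of each other. The 4-hydroxycyclohexyl group of compound 1 still stands clear of the small bare ring, with a 7.8-fold higher number from compound 1 to compound 4 (0.89 log units; beyond the scatter), so ring size alone, from cyclohexyl down to cyclopropyl, did not reproduce or approach that result. Nothing measured alongside these numbers accounts for them.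

Going by these compounds, it remains open whether a hydroxymethyl group on the cyclopropyl ring would give a result like that of compound 1. On these data alone, it is equally open whether an amine in place of the hydroxy on the cyclohexyl ring, or an open chain such as n-butyl on the amide-type nitrogen, would do so.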